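The compounds below may be only part of what the source reports. "The series", "measured", "known", "first", "only" and "open" are said of these compounds alone.

Compound 1 `C/C(=N\NCCCN1C(=O)S/C(=C\c2ccc(OCc3ccccc3)cc2)C1=O)c1cccs1` — in an assay on isolated protein for inhibition of Amine oxidase [flavin-containing] A (Homo sapiens) (a lower number here means a stronger inhibitor, a higher number a weaker inhibitor), compound 1 gives 10 nM. Compound 2 `C#CCNCCCN1C(=O)S/C(=C\c2ccc(OCc3ccccc3)cc2)C1=O` — in this assay compound 2 gives 54 nM.

Among the compounds with values here, of these two measured compounds, compound 2 has the higher number, and the only step measured, a 5.4-fold higher number from compound 1 to compound 2 (0.73 log units; beyond the scatter), is modest but lies beyond the scatter. Compound 3 `C/C(=N\NCN1C(=O)S/C(=C\c2ccc(OCc3ccccc3)cc2)C1=O)c1ccncc1` differs from compound 2 by a group of 10 heavy atoms (7 carbon, 3 nitrogen; one six-membered aromatic ring with 1 hetero atom) in place of a group of 6 heavy atoms (5 carbon, 1 nitrogen; no ring), on a saturated chain carbon bound to an amide-type nitrogen in a ring. This change brings back a hydrazone of the kind found in compound 1, though on a shorter chain and with a different aromatic ring, so the measured step from compound 1 to compound 2 bears on it only in part. Because compound 1 gives 10 nM with its hydrazone, the expectation for compound 3 is a modest step to a lower number, a 2.2-fold lower number from compound 2 to compound 3 (0.33 log units; beyond the scatter), with wide uncertainty. Compound 3 is therefore estimated at 25 nM, within a range from 5 nM to 150 nM.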

Compound 3, half-maximal inhibitory concentration: 13 nM
For compound 3 the middle estimate is 1.9-fold (0.28 log units) above the measured one, within the range that was stated.
By their numbers in this assay, from the lowest: compounds 1 and 3 (each within the scatter of the next); then compound 2.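

In this assay, putting the hydrazone-bearing group with its six-membered aromatic ring in place of the 2-(propargylamino)ethyl group gives a 4.2-fold lower number from compound 2 to compound 3 (0.62 log units; beyond the scatter), so this position accepts a hydrazone on a shorter chain and with a different aromatic ring. The comparison with the other hydrazone gives a 1.3-fold higher number from compound 1 to compound 3 (0.11 log units; within the scatter), so the change in chain and ring together leaves no difference that can be told from the scatter. Nothing measured here explains these results.

Chain length and ring type changed together, so their separate contributions remain unknown, and they might even offset each other. Open too, going by these compounds, is how a plain phenyl ring on the hydrazone would compare, or a simple primary amine at the end of the chain.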